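A few compounds are considered here, and "the series" means these few. Any claim that something is new, unique, unknown or untested is made for them only; others in the source may bear on it.

Compound 1 `COc1ccc(C(OCc2ccccc2)c2cccc3ccccc23)c(OC)c1OC` and compound 2 `C=CCOC(c1ccc(OC)c(OC)c1OC)c1cccc2ccccc12` share one core and differ only where a vinyl stands in place of a phenyl on a saturated chain carbon bound to an oxygen on a saturated carbon. In a functional assay on HCT-116 cells (Homo sapiens) for inhibition, read by sulforhodamine B assay, with a stated time of 48 h (a lower number here means a stronger inhibitor, a higher number a weaker inhibitor), compound 1 gives only a limit, > 20000 nM. Compound 2 likewise gives only a limit in this assay, > 20000 nM. The step that the two limits leave unreadable from compound 1 to compound 2 stays unreadable because the limit of > 20000 nM in this assay, at which 2 of the 2 values shown sit, covers both values, so compound 2 stands at the limit of this assay, with no number to place it.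

Compound 3 `COC(=O)c1ccc(COC(c2ccc(OC)c(OC)c2OC)c2cccc3ccccc23)cc1` differs from compound 2 by 4-(methoxycarbonyl)phenyl in place of vinyl on a saturated chain carbon bound to an oxygen on a saturated carbon, which is allyl to 4-(methoxycarbonyl)benzyl when cut one bond further out. Going by the values given here, the one measured step offers no readable size to carry over. For compound 3 the expected value in this assay is 30000 nM, within 8000 nM to 100000 nM. The step that the limit leaves unreadable from compound 2 to compound 3 is therefore expected to be none beyond the scatter, with another limit the likeliest outcome.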

Compound 3, half-maximal inhibitory concentration: > 20000 nM
Compound 3: a limit, no number; the forecaster's own chance of this, stated with the estimate: 75%; the middle value is on the limit's open side.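

In this assay compound 3, like compound 1 and compound 2, gives only a limit, so no step among these three compounds can be read: the limit of > 20000 nM in this assay, at which 3 of the 3 values shown sit. The compounds shown leave open what value any of them has, and which change to the shared core, if any, would give a readable number.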